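Aryl piperazine series: pyridyl replacement at the ring amine

A few compounds are considered here, and "the series" means these few. Any claim that something is new, unique, unknown or untested is made for them only; others in the source may bear on it.

Compound 2 `CNc1ccccc1N1CCN(CCCCn2ncc(=O)n(C)c2=O)CC1` stands highest of the two numbers given in an assay for displacement of a labelled ligand from Adrenergic receptor alpha-1 (Homo sapiens) (a lower number here means a stronger inhibitor, a higher number a weaker inhibitor), where compound 2 gives 450 nM. Its nearest neighbour, compound 1 `CN(C)c1ccccc1N1CCN(CCCCn2ncc(=O)n(C)c2=O)CC1`, gives 350 nM, and a 1.3-fold higher number from compound 1 to compound 2 (0.11 log units; within the scatter). Compound 3 `Cn1c(=O)cnn(CCCCN2CCN(c3ccc(F)cn3)CC2)c1=O` returns only a limit in this assay, > 10000 nM. The change to compound 4 `Cn1c(=O)cnn(CCCCN2CCN(c3cccc(F)n3)CC2)c1=O` is 6-fluoropyridin-2-yl in place of 2-(methylamino)phenyl on an amine nitrogen in a ring. The closest measured steps are an at least 22-fold higher number from compound 2 to compound 3 (1.34 log units; beyond the scatter) and an at least 28-fold higher number from compound 1 to compound 3 (1.45 log units; beyond the scatter), both reaching (the limit of > 10000 nM in this assay, at which 1 of the 3 values shown sits). On that basis a similarly large rise in the number is expected for compound 4, with a fair chance that only a limit is returned. Compound 4 is therefore estimated at 8000 nM, within 2000 nM to 30000 nM. The expected step is an 18-fold higher number from compound 2 to compound 4 (1.25 log units; beyond the scatter).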

Compound 4, inhibition constant: > 10000 nM
Compound 4 was reported as a limit (the forecaster's own chance of this, stated with the estimate: 60%); middle value at least 1.2-fold (0.09 log units) away from the limit.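

In this assay, 6-fluoropyridin-2-yl on the amine nitrogen in the ring gives an at least 22-fold higher number from compound 2 to compound 4 (1.34 log units; beyond the scatter) and an at least 28-fold higher number from compound 1 to compound 4 (1.45 log units; beyond the scatter), so the large loss seen with 5-fluoropyridin-2-yl is not confined to that one fluoropyridyl group. The value of compound 4 is a limit, and the step between compound 3 and compound 4 cannot be read, so the two fluoropyridyl groups cannot be ranked. Both compounds now rest on the same limit: the limit of > 10000 nM in this assay, at which 2 of the 4 values shown sit.

Still open, as far as these compounds go, is which part of the change carries the loss. A plain phenyl or an unsubstituted pyridin-2-yl on the same nitrogen would separate the amino group from the ring nitrogen and the fluorine.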